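The source may hold more compounds than are shown below. What is called first, only, known or untested is meant among the compounds shown, and "the series" means these compounds.

Measured in an ADME assay on Raji cells (Homo sapiens) for cytotoxicity, with a stated time of 72 h; a higher number here means that more compound is needed for the effect, a lower number that less compound is needed:
- compound 1 `Cc1cc(NC(=O)Nc2ccc(SC(F)(F)F)cc2)c2ccccc2n1`: 10000 nM
- compound 2 `Cc1cc(NC(=O)Nc2ncccc2C)c2ccccc2n1`: > 25000 nM, a limit
- compound 3 `Cc1cc(NC(=O)Nc2ccccc2F)c2ccccc2n1`: > 25000 nM, a limit

Compound 3 has no number in this assay, only the limit > 25000 nM. It sits with one other compound at the limit of > 25000 nM in this assay, at which 2 of the 3 values shown sit.

Compound 4 `Cc1cc(NC(=O)Nc2ccc(Cl)cc2)c2ccccc2n1` is the next entry. The change from compound 3 is 4-chlorophenyl in place of 2-fluorophenyl on an amide-type nitrogen.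

For the measured compounds named here, the one measured step, a step that the two limits leave unreadable from compound 2 to compound 3, gives no size to carry over. Going by the values given here, the only guide to a number is compound 1, which gives 10000 nM with a different group on the same amide-type nitrogen. On that basis, a modest move towards less compound needed is expected, though another limit would be no surprise. The expected size is an at least 1.5-fold lower number from compound 3 to compound 4 (0.19 log units; that floor lies within the scatter), an estimate resting on a single numeric value. For compound 4 the estimated value is 16000 nM, with an expected range of 7000 nM to 25000 nM.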

Compound 4, half-maximal effective concentration: > 25000 nM
Compound 4: a limit, no number (the forecaster's own chance of this, stated with the estimate: 50%); at least 1.5-fold (0.19 log units) between middle value and limit.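

In this assay compound 4 carries only a limit, > 25000 nM, so replacing 2-fluorophenyl with 4-chlorophenyl on the amide-type nitrogen gives no number, and the steps among compound 2, compound 3 and compound 4 cannot be read. For the compounds shown here, the one readable step is chloro in place of (trifluoromethyl)sulfanyl on an aromatic carbon, an at least 2.5-fold higher number from compound 1 to compound 4 (0.39 log units; beyond the scatter). Compound 1 remains the only compound with a number, and the limit now covers most of the set: the limit of > 25000 nM in this assay, at which 3 of the 4 values shown sit.

Open, going by these compounds, is whether the number for compound 1 is tied to (trifluoromethyl)sulfanyl itself or would also come with another group on that aromatic carbon, such as trifluoromethyl, methoxy or an amine. The compounds shown all keep the shared core, so its part in the read-out also stays open.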